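Chain Variation Toward Compound 4 in a Chemokine Receptor Series

The compounds below may be only part of what the source reports. "The series", "measured", "known", "first", "only" and "open" are said of these compounds alone.

Compound 1 `c1cncc(CNCCCCN(C[C@H]2Cc3ccccc3CN2)[C@H]2CCCc3cccnc32)c1`: 15.3 nM
Compound 2 `c1ccc2c(c1)CN[C@@H](CN(CCCCNCc1ccncc1)[C@H]1CCCc3cccnc31)C2`: 22.7 nM
Compound 3 `c1ccc2c(c1)CN[C@@H](CN(CCCCNC1CCOCC1)[C@H]1CCCc3cccnc31)C2`: 29.4 nM

In a functional assay on cells for antagonist activity at C-X-C chemokine receptor type 4 (Homo sapiens), read by fluorescence and calcium flux, with stated times of 25 min and 90 s (a higher number here means a weaker inhibitor, a lower number a stronger inhibitor), compound 3 gives the highest of the three numbers, yet its gaps to compound 2 and to compound 1 both lie within the scatter, so the three compounds are indistinguishable on these data. The change to compound 4 `CC(C)(CCN(C[C@H]1Cc2ccccc2CN1)[C@H]1CCCc2cccnc21)CNCC1CCOCC1` is a group of 12 heavy atoms (10 carbon, 1 nitrogen, 1 oxygen; one six-membered non-aromatic ring with 1 hetero atom) in place of a group of 9 heavy atoms (7 carbon, 1 nitrogen, 1 oxygen; one six-membered non-aromatic ring with 1 hetero atom), on a saturated chain carbon, two bonds along the chain from an amine nitrogen. Going by the values given here, no measured step touches this part of the molecule. The steps seen so far exchanged only the group at the end of the chain: a 1.9-fold higher number from compound 1 to compound 3 (0.28 log units; within the scatter) and a 1.3-fold higher number from compound 2 to compound 3 (0.11 log units; within the scatter), both within the scatter, as was a 1.5-fold higher number from compound 1 to compound 2 (0.17 log units; within the scatter). They show that the end of the chain tolerates several groups without a change beyond the scatter, but they say nothing about altering the chain itself, which compound 4 does. The expectation for compound 4 therefore rests on little: a step of a 1.4-fold higher number from compound 3 to compound 4 (0.13 log units; within the scatter) is expected, with a wide range. Compound 4 is estimated at 40 nM in this assay, between 12 nM and 130 nM.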

Compound 4, half-maximal inhibitory concentration: 43.8 nM
Compound 4: the middle estimate sits 1.1-fold (0.04 log units) below what was measured; measured number inside the range.
By their numbers in this assay, from the lowest: compounds 1, 2, 3 and 4 (each within the scatter of the next, the first and the last beyond it).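

Going by these compounds alone, this is the first step that alters the chain itself rather than only the group at its end. In this assay, within the data shown here, the group of 12 heavy atoms replacing 2-((oxan-4-yl)amino)ethyl gives a 1.5-fold higher number from compound 3 to compound 4 (0.17 log units; within the scatter) and so this position accepts the larger group without a change beyond the scatter, as it does with a 1.9-fold higher number from compound 2 to compound 4 (0.29 log units; within the scatter) while a 2.9-fold higher number from compound 1 to compound 4 (0.46 log units; beyond the scatter) is the first gap to pass beyond the scatter, though only modestly. Nothing available here explains why these numbers fall as they do.

Still open, going by these compounds, is how a shorter chain, or a longer one, would read at this position. On these data alone, it is also open whether a chain ending in a carboxylic acid would stay as close to compound 3 as compound 4 does.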